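Ester in place of acid on a sulfone-bearing nucleoside

A few compounds are considered here, and "the series" means these few. Any claim that something is new, unique, unknown or untested is made for them only; others in the source may bear on it.

Of the compounds shown here, three have been measured in a functional assay on MT4 cells (Homo sapiens); on this read-out higher numbers stand for lower toxicity in this test and lower numbers for higher toxicity in this test. Compound 1 `Cc1cn([C@@H]2O[C@@H]3COC4(O)CS(=O)(=O)O[C@@]34[C@H]2O[Si](C)(C)C(C)(C)C)c(=O)[nH]c1=O` gives 100000 nM and compound 3 `Cc1cn([C@@H]2O[C@@H]3COC4(O)CS(=O)(=O)O[C@@]34[C@H]2O)c(=O)[nH]c1=O` gives 100000 nM; the step of no change at the digits printed from compound 1 to compound 3 (within the scatter) shows that removing the silyl group on the secondary oxygen left the read-out where it was. Compound 2 `Cc1cn([C@@H]2O[C@H](CO[Si](C)(C)C(C)(C)C)[C@@]3(OS(=O)(=O)C=C3NCCC(=O)O)[C@H]2O[Si](C)(C)C(C)(C)C)c(=O)n(C)c1=O` gives 11500 nM, the lowest of the three numbers, standing about as far below compound 1 as below compound 3, and both gaps lie beyond the scatter.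

Compound 4 `Cc1cn([C@@H]2O[C@H](CO[Si](C)(C)C(C)(C)C)[C@@]3(OS(=O)(=O)C=C3NCC(=O)OCc3ccccc3)[C@H]2O[Si](C)(C)C(C)(C)C)c(=O)n(C)c1=O` differs from compound 2 in a single place: benzyloxycarbonyl in place of carboxymethyl on a saturated chain carbon bound to an amine nitrogen. Going by the values given here, no measured step touches this kind of change; the only step known, from compound 1 to compound 3, alters a silyl ether elsewhere on the core and tells nothing about the amine side chain. Among the compounds with values here, with no step bearing on it, compound 4 is expected to land near compound 2, and the step of a 1.3-fold higher number from compound 2 to compound 4 (0.12 log units; within the scatter) is estimated as small, without a clear direction. Compound 4 is therefore estimated at 15000 nM, within 4000 nM to 60000 nM.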

Compound 4, half-maximal cytotoxic concentration: 250000 nM
The estimate for compound 4 lay 17-fold (1.22 log units) below the measured number, and the stated range ends below it.
By their numbers in this assay, from the lowest: compound 2; then compounds 1 and 3 (each within the scatter of the next); then compound 4.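

Going by these compounds alone, the amine side chain proved to be a sensitive place in this assay: a 22-fold higher number from compound 2 to compound 4 (1.34 log units; beyond the scatter), whereas the only earlier step, which concerned a silyl ether elsewhere on the core, gave no such shift. Read at one bond further out, the change replaces 2-carboxyethyl with (benzyloxycarbonyl)methyl, so this single step exchanges a group with one hydrogen-bond donor for one with none and brings in a six-membered aromatic ring of carbon only. Nothing available explains why the number rises this far.

The compounds shown do not separate the loss of the carboxylic acid from the gain of the benzyl ring or the change in the chain. Going by these compounds, it remains open whether a methyl ester or a primary amide on the 2-carboxyethyl chain would read like compound 2 or like compound 4.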